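The source may report more compounds than this note shows. Statements on the series, on what has been measured and on what is new or still open speak of the compounds shown alone.

Compound 1 `COC(=O)/C(=C\c1ccc(OC(=O)c2cccc(OC)c2)cc1)Sc1ccnc2cc(Cl)ccc12`: 25500 nM
Compound 2 `COC(=O)/C(=C\c1ccc(OC(=O)c2cc(OC)cc(OC)c2)cc1)Sc1ccnc2cc(Cl)ccc12`: 19000 nM
Compound 3 `COC(=O)/C(=C\c1ccc(OC(=O)c2ccc(OC)c(OC)c2)cc1)Sc1ccnc2cc(Cl)ccc12`: 5290 nM

In a functional assay on HL-60 cells (Homo sapiens) for cytotoxicity, read by MTT assay, with a stated time of 24 h (a lower number here means a stronger inhibitor, a higher number a weaker inhibitor), compound 1 gives 25500 nM, which puts it at the weak end of this small set, within the scatter of compound 2. Compound 4 `COC(=O)/C(=C\c1ccc(OC(=O)c2cccc(OC)c2OC)cc1)Sc1ccnc2cc(Cl)ccc12` differs from compound 1 by methoxy in place of hydrogen on an aromatic carbon, so that 3-methoxyphenyl becomes 2,3-dimethoxyphenyl. Two measured steps add a methoxy to the same ring, though neither at this place. One is a 1.3-fold lower number from compound 1 to compound 2 (0.13 log units; within the scatter), and the other is a 4.8-fold lower number from compound 1 to compound 3 (0.68 log units; beyond the scatter). A lower number is therefore expected, by a modest amount or by little more than the scatter. The expected step is a 2.0-fold lower number from compound 1 to compound 4 (0.29 log units; within the scatter). Compound 4 is estimated at 13000 nM, with an expected range from 5000 nM to 30000 nM.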

Compound 4, half-maximal inhibitory concentration: 13000 nM
Compound 4: middle estimate and measured number agree at the digits printed; low and high end bracket the measured number.
By their numbers in this assay, from the lowest: compound 3; then compounds 4, 2 and 1 (each within the scatter of the next).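

In this assay, a methoxy placed ortho to a methoxy group changes little, with a 2.0-fold lower number from compound 1 to compound 4 (0.29 log units; within the scatter) as the step. The site of the second methoxy does matter, though: the 2,3-dimethoxyphenyl group cannot be told apart from the 3,5-dimethoxyphenyl group (a 1.5-fold lower number from compound 2 to compound 4 (0.16 log units; within the scatter)), yet it falls short of the 3,4-dimethoxyphenyl group (a 2.5-fold higher number from compound 3 to compound 4 (0.39 log units; beyond the scatter)). Nothing available here explains this difference between the two placements.

Still open, as far as these compounds go, is whether a group other than methoxy at this place, such as a hydroxyl, an amine or a longer alkoxy chain, would shift the number further.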